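Notes on compound 2 and its methyl ester analogue compound 3

A few compounds are considered here, and "the series" means these few. Any claim that something is new, unique, unknown or untested is made for them only; others in the source may bear on it.

Measured compounds:
compound 1: `C=C1C(=O)O[C@H]2C/C(C)=C/[C@@H](O)C/C(C)=C/CC/C(C)=C/C[C@H]12` — > 5 ug/mL
compound 2: `C=C1C(=O)O[C@H]2/C=C(\C)CC/C=C(\CO)CC/C=C(\C)CC[C@@H]12` — > 5 ug/mL

Both measurements come from a functional assay on Hep 3B2 cells (Homo sapiens) for cytotoxicity, read by MTT assay; on this read-out higher numbers stand for weaker inhibition and lower numbers for stronger inhibition. Compound 1 gives > 5 ug/mL, which is a limit of the assay and not a number. Compound 2 gives > 5 ug/mL, likewise a limit. Compound 2 therefore stands where every value shown stands: at the limit of > 5 ug/mL in this assay, at which 2 of the 2 values shown sit. Within the data shown here, with only limits in hand, no step between the measured compounds can be sized, and no pattern is claimed from them.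

The compound still to be tested is compound 3, `C=C1C(=O)O[C@H]2/C=C(\C)CC/C=C(\C(=O)OC)CC/C=C(\C)CC[C@@H]12`. It differs from compound 2 by methoxycarbonyl in place of hydroxymethyl on a double-bonded ring carbon. The rest of the shared core is unchanged.

For compound 3 the expected step is a step that the limit leaves unreadable from compound 2 to compound 3, that is none beyond the scatter, because both measured compounds sit at the limit of > 5 ug/mL in this assay, at which 2 of the 2 values shown sit, and give no basis for a change in either direction. Compound 3 is expected at 8 ug/mL, within 4 ug/mL to 20 ug/mL, and most probably this assay will again report only a limit.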

Compound 3, half-maximal inhibitory concentration: > 5 ug/mL
Compound 3 gave a limit, no number; the forecaster's own chance of this, stated with the estimate: 70%; the middle value lies beyond the limit too.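

In this assay compound 3 gives > 5 ug/mL, a limit and not a number. No step can be read between compound 2 and compound 3, which differ by methoxycarbonyl in place of hydroxymethyl: the limit of > 5 ug/mL in this assay, at which 3 of the 3 values shown sit.

The compounds shown leave open whether either group, or any change to the shared core, gives a measurable value in this assay.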